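The source may report more compounds than this note shows. Statements on the series, on what has been measured and on what is new or still open speak of the compounds shown alone.

Compounds measured so far in a functional assay on L1210 cells (Mus musculus) for inhibition; on this read-out lower numbers stand for stronger inhibition and higher numbers for weaker inhibition

- compound 1 (`COC1=CC(=O)c2ncnc(NCCCN(C)C)c2C1=O`) gives (0.501 ug/mL)
- compound 2 (`CN(C)CCCNc1ncnc2c1C(=O)C(N1CCCCC1)=CC2=O`) gives (0.406 ug/mL)

Going by the values given here, these two numbers cannot be ranked, so compound 1 stands level with the only other compound measured. Among the compounds with values here, the single measured step (a 1.2-fold lower number from compound 1 to compound 2 (0.09 log units; within the scatter)) lies within the scatter.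

Compound 3 (`COC(=O)CNc1ncnc2c1C(=O)C(OC)=CC2=O`) keeps the core of compound 1 but alters its side chain (methoxycarbonyl in place of 2-(dimethylamino)ethyl on a saturated chain carbon bound to a nitrogen on an aromatic ring), with methoxycarbonyl in place of 2-(dimethylamino)ethyl. That measured step concerns a double-bonded ring carbon, not this chain, so it gives no direct guide to the size of the new step. The data hold no measured change of the side chain. A moderate move towards a higher number is therefore expected, though only tentatively, and a result within the scatter would not be surprising. The estimated step is (a 3.0-fold higher number from compound 1 to compound 3 (0.48 log units; beyond the scatter)). Compound 3 is expected at (1.5 ug/mL), with an estimated range from (0.4 ug/mL) to (6 ug/mL).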

Compound 3, half-maximal inhibitory concentration: 1.2 ug/mL
Estimate against measurement, compound 3: 1.3-fold (0.10 log units) above; low and high end bracket the measured number.
By their numbers in this assay, from the lowest: compounds 2 and 1 (each within the scatter of the next); then compound 3.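

In this assay the side chain turns out to be a place where a change can be read: methoxycarbonyl in place of 2-(dimethylamino)ethyl gives a 2.4-fold higher number from compound 1 to compound 3 (0.38 log units; beyond the scatter) and so weakens inhibition modestly. Going by these compounds alone, the only earlier step, at the double-bonded ring carbon, gave a 1.2-fold lower number from compound 1 to compound 2 (0.09 log units; within the scatter) and showed no readable change. Compound 3 lacks the dimethylamino group yet keeps a modest loss rather than a large one, and no measurement here accounts for this step.

The step changes the end group and the chain together, as 3-(dimethylamino)propyl to (methoxycarbonyl)methyl, so the compounds shown leave open which of the two carries it. A methoxycarbonyl group on a longer chain or a dimethylamino group on a shorter one would separate them, and a carboxylic acid at the chain end remains an open case.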